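Working notes: bromo to trifluoromethyl on compound 3

The source may report more compounds than this note shows. Statements on the series, on what has been measured and on what is new or still open speak of the compounds shown alone.

Values in an ADME assay on Vero 76 cells (Chlorocebus sabaeus) for cytotoxicity, read by MTT assay, with a stated time of 96 h (on this read-out lower numbers stand for higher toxicity in this test and higher numbers for lower toxicity in this test), so far:
compound 1 `FC(F)(F)c1ccc(-c2nn(-c3ccccc3)cc2CNc2ccc(Cl)cc2)cc1` gives 10000 nM
compound 2 `Cc1ccc(NCc2cn(-c3ccccc3)nc2-c2ccc(C(F)(F)F)cc2)cc1` gives 82000 nM
compound 3 `FC(F)(F)c1ccc(NCc2cn(-c3ccccc3)nc2-c2ccc(Br)cc2)cc1` gives 28000 nM

Compound 3 holds the middle place of the three numbers in this assay. Compound 3 gives 28000 nM, while compound 1 gives 10000 nM and compound 2 gives 82000 nM, so compound 3 stands above compound 1 and below compound 2, with both gaps beyond the scatter.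

Going to compound 4 `FC(F)(F)c1ccc(NCc2cn(-c3ccccc3)nc2-c2ccc(C(F)(F)F)cc2)cc1`, the change trifluoromethyl in place of bromo on an aromatic carbon puts trifluoromethyl in place of bromo on an aromatic carbon, para to a large group. The 4-(trifluoromethyl)phenyl group that results is already carried by compound 1 and compound 2.

For the measured compounds named here, no measured step makes this exchange. Going by the values given here, the only step available, an 8.2-fold higher number from compound 1 to compound 2 (0.91 log units; beyond the scatter), swaps different groups at another place in the structure. It shows that a single substitution can move the number in this series, but it gives no direction for the present change. No step beyond the scatter is therefore expected, though the range is kept wide. The expected outcome is a 1.1-fold higher number from compound 3 to compound 4 (0.03 log units; within the scatter) and this estimate carries no firm direction.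

Compound 4 is expected at an estimated 30000 nM in a range from 10000 nM to 90000 nM on this read-out.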

Compound 4, half-maximal cytotoxic concentration: 26000 nM
For compound 4 the middle estimate is 1.2-fold (0.06 log units) above the measured one; the range from low to high includes it.
By their numbers in this assay, from the lowest: compound 1; then compounds 4 and 3 (each within the scatter of the next); then compound 2.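

In this assay the change from 4-bromophenyl to 4-(trifluoromethyl)phenyl gives (a 1.1-fold lower number from compound 3 to compound 4 (0.03 log units; within the scatter)). Bromo and trifluoromethyl are therefore not told apart at this position, on an aromatic carbon para to a large group, although the entering group has four heavy atoms and the leaving one has one. Compound 4 also adds a third group at the other varied place, where the steps are larger: trifluoromethyl in place of methyl gives (a 3.2-fold lower number from compound 2 to compound 4 (0.50 log units; beyond the scatter)) and trifluoromethyl in place of chloro gives (a 2.6-fold higher number from compound 1 to compound 4 (0.41 log units; beyond the scatter)), which together put the trifluoromethyl compound between the chloro and methyl compounds on this read-out.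

The compounds shown leave open whether this position stays as flat with a group of a different kind, such as an amine or a carboxylic acid, since only bromo and trifluoromethyl can be compared here. They also leave open whether the steps at the other varied place would keep their size with bromo in place of trifluoromethyl at this position.

No measured evidence bears on why these numbers fall as they do.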